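Extending the sulfur side chain of compound 2

The compounds below may be only part of what the source reports. "The series", "measured", "known", "first", "only" and "open" are said of these compounds alone.

In a functional assay on HT-29 cells (Homo sapiens) for inhibition, read by MTT assay, with a stated time of 48 h (on this read-out higher numbers stand for weaker inhibition and lower numbers for stronger inhibition), compound 1 (`CCSc1nnc(-c2cc(OC)c(OC)c(OC)c2)n1-c1ccc(OC)cc1`) gives > 60000 nM which is a limit of the assay. Compound 2 (`COc1ccc(-n2c(SCc3ccccc3)nnc2-c2cc(OC)c(OC)c(OC)c2)cc1`) gives > 60000 nM which is likewise a limit, so it stands at the limit of > 60000 nM in this assay, at which 2 of the 3 values shown sit, without a number of its own. Among the measured compounds shown here, compound 3 (`COc1ccc(-n2c(SCC(=O)c3ccc(F)cc3)nnc2-c2cc(OC)c(OC)c(OC)c2)cc1`) reads 42500 nM as the only true number so far. Compound 4 (`COc1ccc(-n2c(SCC(=O)c3ccc4ccccc4c3)nnc2-c2cc(OC)c(OC)c(OC)c2)cc1`) awaits measurement and differs from compound 2 by (naphthalen-2-yl)carbonyl in place of phenyl on a saturated chain carbon bound to a sulfur. For the measured compounds named here, the closest precedent is the (4-fluorophenyl)carbonyl of compound 3, which gives an at least 1.4-fold lower number from compound 2 to compound 3 (0.14 log units; that floor lies within the scatter) and an at least 1.4-fold lower number from compound 1 to compound 3 (0.14 log units; that floor lies within the scatter) while a step that the two limits leave unreadable from compound 1 to compound 2 adds nothing. Both floors lie within the scatter, so only a modest lowering is expected in this assay and a reading at the limit remains possible. The expected change is an at least 2.4-fold lower number from compound 2 to compound 4 (0.38 log units; beyond the scatter) as an estimate only. Compound 4 is expected at 25000 nM with an estimated range from 6000 nM to 60000 nM in this assay when measured.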

Compound 4, half-maximal inhibitory concentration: 53400 nM
Estimate against measurement, compound 4: 2.1-fold (0.33 log units) below, within the range that was stated.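

In this assay, the larger (naphthalen-2-yl)carbonyl gives an at least 1.1-fold lower number from compound 2 to compound 4 (0.05 log units; that floor lies within the scatter) and an at least 1.1-fold lower number from compound 1 to compound 4 (0.05 log units; that floor lies within the scatter), so neither step shows a lowering beyond the scatter. Naphthalen-2-yl in place of 4-fluorophenyl on the carbonyl carbon gives a 1.3-fold higher number from compound 3 to compound 4 (0.10 log units; within the scatter), which is also within the scatter, so the second aromatic ring of carbon only brings no readable change at this position. Both compounds with a carbonyl in the side chain give true numbers, whereas compound 1 and compound 2 stay at a limit of the assay: the limit of > 60000 nM in this assay, at which 2 of the 4 values shown sit.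

From the compounds shown here alone, it remains open whether an amine or a carboxylic acid in place of the naphthalen-2-yl would take the number beyond the scatter. Going by these compounds, it is equally open how a hydroxyl in place of the carbonyl oxygen, or a longer chain on the sulfur, would read.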